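A few compounds are considered here, and "the series" means these few. Any claim that something is new, unique, unknown or untested is made for them only; others in the source may bear on it.

Measured so far:
compound 1 `C[C@H]1[C@H](NCc2cc(C3CC3)cs2)C[C@H]2C[C@@H]1C2(C)C`: 25000 nM in an ADME assay on MDCK cells (Canis lupus familiaris) for cytotoxicity, read by microscopy, with a stated time of 48 h; on this read-out lower numbers stand for higher toxicity in this test and higher numbers for lower toxicity in this test
compound 2 `C[C@H]1[C@H](NCc2cncs2)C[C@H]2C[C@@H]1C2(C)C`: > 100000 nM in this assay
compound 3 `C[C@H]1[C@H](NCc2sccc2C2CC2)C[C@H]2C[C@@H]1C2(C)C`: 25000 nM in this assay

For compound 2 the read-out is only a limit of this assay, namely (the limit of > 100000 nM in this assay, at which 1 of the 3 values shown sits), so no number is known for it. Compound 1 and compound 3 each return a measured number, and the two lie within the scatter of each other. Compound 4 `Cc1csc(CN[C@@H]2C[C@H]3C[C@@H]([C@H]2C)C3(C)C)n1` differs from compound 2 by 4-methyl-1,3-thiazol-2-yl in place of 1,3-thiazol-5-yl on a saturated chain carbon bound to an amine nitrogen. Going by the values given here, no measured pair carries a change of this kind, so the expected step of an at least 1.6-fold lower number from compound 2 to compound 4 (0.22 log units; that floor lies within the scatter) is small and, if anywhere, points towards a measurable number. For compound 4 in this assay the estimate is 60000 nM, within 20000 nM to 100000 nM, with a fair chance that only a limit is returned once more.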

Compound 4, minimum cytotoxic concentration: > 100000 nM
Compound 4 ended at the assay's limit; the forecaster's own chance of this, stated with the estimate: 50%; at least 1.6-fold (0.22 log units) between middle value and limit.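

Compound 2 and compound 4 both end at an assay limit, so no step between them can be read: the limit of > 100000 nM in this assay, at which 2 of the 4 values shown sit.

The compounds shown leave open whether 4-methyl-1,3-thiazol-2-yl in place of 1,3-thiazol-5-yl shifts the read-out in this assay at all.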